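A Ring Change on the Saturated Carbon of Compound 1

The source may hold more compounds than are shown below. What is called first, only, known or untested is meant among the compounds shown, and "the series" means these compounds.

Of the compounds shown here, three with a shared core have been tested in an assay on isolated protein (Cricetulus griseus) for binding affinity to Alpha-1B adrenergic receptor (Mesocricetus auratus), read by radioligand binding; on this read-out lower numbers stand for stronger inhibition and higher numbers for weaker inhibition. Going by the values given here, compound 1 `CS(=O)(=O)Nc1cccc2c1CCCC2C1=NCCN1` is the only one with a real number: in this assay compound 1 gives 7410 nM. Compound 2 `CS(=O)(=O)Nc1ccc(F)c2c1CCCC2c1c[nH]cn1` reaches only a limit of the assay, and in this assay compound 2 gives < 10000 nM. Compound 3 `CC(C)S(=O)(=O)Nc1cccc2c1CCCC2c1c[nH]cn1` likewise reaches only a limit, and in this assay compound 3 gives < 10000 nM. The weak end of the range is therefore marked by the limit of < 10000 nM in this assay, at which 2 of the 3 values shown sit, and compound 1 stands a little inside that edge.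

Compound 4 `Cn1cncc1C1CCCc2c(NS(C)(=O)=O)cccc21` has not yet been measured. It differs from compound 1 in one place, on a saturated ring carbon: a group of 6 heavy atoms (4 carbon, 2 nitrogen; one five-membered aromatic ring with 2 hetero atoms) in place of a group of 5 heavy atoms (3 carbon, 2 nitrogen; one five-membered non-aromatic ring with 2 hetero atoms), on a saturated ring carbon. The group that leaves carries 1 hydrogen-bond donor, the 1-methyl-1H-imidazol-5-yl that enters carries none, and a non-aromatic ring becomes an aromatic one.

Among the compounds with values here, with no measured step of this kind to lean on, the expectation is a loss of binding of modest size, a 2.0-fold higher number from compound 1 to compound 4 (0.31 log units; beyond the scatter), which may not exceed the usual scatter. Compound 4 is estimated to give about 15000 nM, within a range from 5000 nM to 50000 nM. A result reported only as a limit is quite possible.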

Compound 4, inhibition constant: < 10000 nM
Compound 4 was reported as a limit; the forecaster's own chance of this, stated with the estimate: 60%; middle value at least 1.5-fold (0.17 log units) from the limit.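

Compound 4 gives < 10000 nM, which is a limit and not a number. No size can be read for its change from compound 1, because the comparison rests on this limit: the limit of < 10000 nM in this assay, at which 3 of the 4 values shown sit. The compounds shown leave open whether the 1-methyl-1H-imidazol-5-yl on the saturated ring carbon gives stronger or weaker binding than the group in compound 1.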